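A few compounds are considered here, and "the series" means these few. Any claim that something is new, unique, unknown or untested is made for them only; others in the source may bear on it.

Measured so far in a functional assay on RAW264.7 cells (Mus musculus) for inhibition, read by Griess assay, with a stated time of 24 h; a higher number here means a weaker inhibitor, a lower number a stronger inhibitor
- compound 1 `COc1cc(C(O)C(O)C(O)CC(O)C(O)Cc2ccc(O)cc2)ccc1O` gives 46700 nM
- compound 2 `Oc1ccc(CC[C@@H]2C[C@@H](O)C[C@H](c3ccc(O)c(O)c3)O2)cc1` gives 27900 nM

Compound 2 stands within the scatter of compound 1, so these two numbers give no ranking. Going by the values given here, both are the only values available for the series.

Compound 3 `Oc1ccc(CC[C@H]2C[C@@H](O)C[C@@H](c3ccc(O)c(O)c3)O2)cc1` is the next to be read. Against compound 2 the change is the two compounds have the same atoms and bonds and differ only in configuration as drawn: 2 of 3 stereo elements differ; a stereocentre at a saturated ring carbon is drawn R in compound 2 and S in compound 3; a stereocentre at a saturated ring carbon is drawn R in compound 2 and S in compound 3 and nothing else: the two compounds have the same atoms and bonds and differ only in configuration as drawn, with a stereocentre at a saturated ring carbon drawn R in compound 2 and S in compound 3, at two places.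

Among the compounds with values here, no measured pair shows what a change of configuration does in this assay so this step has no direct precedent. No direction is favoured, and no step beyond the scatter is expected, although the range is kept wide. The expected step is small, a 1.1-fold higher number from compound 2 to compound 3 (0.03 log units; within the scatter) as estimated. For compound 3 the estimated value is 30000 nM with an expected range from 12000 nM to 70000 nM in this assay.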

Compound 3, half-maximal inhibitory concentration: 17300 nM
The estimate for compound 3 lay 1.7-fold (0.24 log units) above the measured number; the measured number falls inside the stated range.
By their numbers in this assay, from the lowest: compounds 3, 2 and 1 (each within the scatter of the next, the first and the last beyond it).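

In this assay the pair with the same atoms and bonds, with two stereocentres at saturated ring carbons drawn R in compound 2 and S in compound 3, gives a 1.6-fold lower number from compound 2 to compound 3 (0.21 log units; within the scatter). This pair gives the series its first direct reading of a change of configuration, and at these two ring carbons the change together does not carry the number beyond the usual scatter. Any effect read from this pair can be assigned to configuration alone because no other structural difference separates the two compounds: the fact that compounds 2 and 3 differ only in the configuration as drawn.

As far as these compounds go, the pair changes both ring carbons at once, so the contribution of each one alone remains open, as does any effect that the two changes may hide from each other. Also open, from the compounds shown here alone, is how the number responds to a change of the groups themselves, such as an amine or a carboxylic acid in place of one of the hydroxyl groups on the shared core.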